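The compounds below may be only part of what the source reports. "The series", "measured", "known", "first", "only" and "open" are said of these compounds alone.

Compound 1 `CCNC(=O)c1cc(Oc2ccc(NC(=O)c3nn(-c4ccccc4OC(F)(F)F)c(=O)cc3C)cc2)ccn1` is the starting point. In a functional assay on MCF7 cells (Homo sapiens) for antiproliferative activity, read by MTT assay, with a stated time of 72 h (a higher number here means a weaker inhibitor, a lower number a stronger inhibitor), compound 1 gives 15500 nM, the lowest of the two numbers measured here. Compound 3 `CNC(=O)c1cc(Oc2ccc(NC(=O)c3nn(-c4cccc(C(F)(F)F)c4)c(=O)cc3C)cc2F)ccn1` gives 45800 nM in this assay, a gap from compound 1 that is beyond the usual scatter. Compound 2 `CCCNC(=O)c1cc(Oc2ccc(NC(=O)c3nn(-c4ccc(Br)cc4F)c(=O)cc3C)cc2F)ccn1` is reported in this assay as "not active" (no number reported), with no number attached.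

Compound 4 `CCNC(=O)c1cc(Oc2ccc(NC(=O)c3nn(-c4ccc(Br)cc4F)c(=O)cc3C)cc2)ccn1` has not been measured. It differs from compound 1 in one place: 4-bromo-2-fluorophenyl in place of 2-(trifluoromethoxy)phenyl on an aromatic nitrogen. Going by the values given here, no pair of measured compounds shows this exact change on its own, so the size of the step can only be expected, not read off. Compound 2 carries the same 4-bromo-2-fluorophenyl group as compound 4 and is reported as not active, though it also differs from compound 4 elsewhere. On that basis compound 4 is expected to be weaker than compound 1, with an estimated step of a 2.6-fold higher number from compound 1 to compound 4 (0.41 log units; beyond the scatter) in this assay, likely beyond the scatter. For compound 4 the estimate in this assay is 40000 nM, within a range from 12000 nM to 150000 nM.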

Compound 4, half-maximal inhibitory concentration: 35100 nM
The estimate for compound 4 lay 1.1-fold (0.06 log units) above the measured number, within the range that was stated.
By their numbers in this assay, from the lowest: compound 1; then compounds 4 and 3 (each within the scatter of the next).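

In this assay, going by these compounds alone, putting 4-bromo-2-fluorophenyl in place of 2-(trifluoromethoxy)phenyl on the aromatic nitrogen gives a 2.3-fold higher number from compound 1 to compound 4 (0.35 log units; beyond the scatter), the only direct reading here of a change at this position with the rest of the molecule held fixed. The read-out therefore responds to the group at this position, although the step is modest, and the 4-bromo-2-fluorophenyl group still allows a measurable number, with compound 4 at 35100 nM. Nothing available here accounts for the size or direction of this step.

The change swaps several features at once, so the separate contributions of the bromine, the fluorine and the lost trifluoromethoxy group stay unresolved. Also open, going by these compounds, is how an unsubstituted phenyl, or a phenyl carrying an amine or a carboxylic acid, would behave at this position.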